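A few compounds are considered here, and "the series" means these few. Any claim that something is new, unique, unknown or untested is made for them only; others in the source may bear on it.

Compound 1 `Cn1ccc2cc(-c3ccc4oc(Nc5ccccn5)nc4c3)ccc21` and compound 2 `CNc1nc2cc(-c3ccc4c(ccn4C)c3)ccc2o1` share one core and differ only in the group on the amine nitrogen. In an assay on HEK293 cells for inhibition of Fatty-acid amide hydrolase 1 (Homo sapiens), read by fluorescence (on this read-out higher numbers stand for weaker inhibition and lower numbers for stronger inhibition), compound 1 gives 186 nM. On these data alone, compound 2 reaches only the limit of this assay, > 1000 nM, so its number is unknown. Going by the values given here, the single measured step, an at least 5.3-fold higher number from compound 1 to compound 2 (0.73 log units; beyond the scatter), shows that swapping pyridin-2-yl for methyl weakened inhibition. Compound 3 `Cn1ccc2cc(-c3ccc4oc(N5CCCC5)nc4c3)ccc21` differs from compound 2 by pyrrolidin-1-yl in place of methylamino on an aromatic carbon. Among the compounds with values here, no measured step tests this change, so a limit is again possible. Compound 3 is expected to give about 1500 nM, between 300 nM and 8000 nM, an estimated step that the limit leaves unreadable from compound 2 to compound 3.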

Compound 3, half-maximal inhibitory concentration: 674 nM
Compound 3: the middle estimate sits 2.2-fold (0.35 log units) above what was measured; the range from low to high includes it.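

Pyrrolidin-1-yl, which has 0 hydrogen-bond donors, gives a readable number at this aromatic carbon, with an at least 1.4-fold lower number from compound 2 to compound 3 (0.17 log units; that floor lies within the scatter). Against (pyridin-2-yl)amino, the same ring gives a 3.6-fold higher number from compound 1 to compound 3 (0.56 log units; beyond the scatter), so compound 1 keeps the lowest number of the three. The true gap on the methylamino side cannot be read, because compound 2 stands at a limit: the limit of > 1000 nM in this assay, at which 1 of the 3 values shown sits.

Still open, on these data alone, is whether the lower number of compound 1 depends on its pyridine ring or on its amine hydrogen. A phenylamino or a piperidin-1-yl group at this place would help to separate the two.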